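From pyrazin-2-yl to pyrimidin-2-yl on compound 3

The source may hold more compounds than are shown below. What is called first, only, known or untested is meant among the compounds shown, and "the series" means these compounds.

Values measured in a functional assay on L5178Y cells (Mus musculus) for cytotoxicity, read by MTT assay; a higher number here means a weaker inhibitor, a lower number a stronger inhibitor:
- compound 1 `CCC(C)(C)c1ccc(OCCCCN2CCN(c3cccnc3)CC2)cc1` gives 9.23 nM
- compound 2 `CC(=O)c1ccc(OCCCCN2CCN(c3ncccn3)CC2)cc1` gives > 100 nM (a limit, not a number)
- compound 3 `CCC(C)(C)c1ccc(OCCCCN2CCN(c3cnccn3)CC2)cc1` gives 12.6 nM

Compound 3 (12.6 nM) stands within the scatter of compound 1. Compound 2 offers only a limit for comparison.

Compound 4 `CCC(C)(C)c1ccc(OCCCCN2CCN(c3ncccn3)CC2)cc1` has the same atoms as compound 3, joined differently, with pyrimidin-2-yl in place of pyrazin-2-yl on an amine nitrogen in a ring.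

Going by the values given here, only one measured step changes a group at this place: pyrazin-2-yl in place of pyridin-3-yl (a 1.4-fold higher number from compound 1 to compound 3 (0.14 log units; within the scatter)). That step stays within the scatter. Among the compounds with values here, compound 2 also carries pyrimidin-2-yl, but it has no measured step to any other compound. With so little evidence, no step beyond the scatter is expected in this assay, and no direction can be favoured.

The estimated step (a 1.0-fold higher number from compound 3 to compound 4 (0.01 log units; within the scatter)) is expected to stay within the scatter. Compound 4 is expected at 13 nM (estimated range 5 nM to 35 nM).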

Compound 4, half-maximal inhibitory concentration: 46.4 nM
Beside the measured number, compound 4's estimate is 3.6-fold (0.55 log units) below it; the whole stated range lies below it.
By their numbers in this assay, from the lowest: compounds 1 and 3 (each within the scatter of the next); then compound 4. At a limit, above all of these: compound 2.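

The group on this amine nitrogen matters in this assay: pyrimidin-2-yl in place of pyrazin-2-yl brings a 3.7-fold higher number from compound 3 to compound 4 (0.57 log units; beyond the scatter), and pyrimidin-2-yl in place of pyridin-3-yl brings a 5.0-fold higher number from compound 1 to compound 4 (0.70 log units; beyond the scatter), while the earlier change at this place stayed within the scatter. The two groups in the first of these steps have the same counts of heavy atoms, donors and acceptors, so those counts alone do not tell such groups apart here. At the other end of the molecule, 1,1-dimethylpropyl in place of acetyl on an aromatic carbon brings an at least 2.1-fold lower number from compound 2 to compound 4 (0.33 log units; beyond the scatter), a step whose starting value is a limit and not a number: the limit of > 100 nM in this assay, at which 1 of the 4 values shown sits.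

From the compounds shown here alone, it remains open whether a phenyl ring, a pyridin-2-yl ring or a plain methyl on this nitrogen would sit nearer compound 1 and compound 3 or nearer compound 4. A shorter or longer chain in the core is also untested by these compounds.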